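Naphthalen-1-yl ketone in a chromene series: what to expect

The source may hold more compounds than are shown below. What is called first, only, known or untested is meant among the compounds shown, and "the series" means these compounds.

Measured compounds:
compound 1 `CC(=O)CC1Oc2cc(O)ccc2C=C1c1ccc(O)cc1`: 145000 nM
compound 2 `CCc1ccc(C(=O)CC2Oc3cc(O)ccc3C=C2c2ccc(O)cc2)cc1`: 198000 nM
compound 3 `COc1ccc(C(=O)CC2Oc3cc(O)ccc3C=C2c2ccc(O)cc2)cc1`: 7600 nM

In a functional assay on MDA-MB-231 cells (Homo sapiens) for antiproliferative activity, read by spectrophotometry and resazurin assay, with a stated time of 72 h (on this read-out higher numbers stand for weaker inhibition and lower numbers for stronger inhibition), compound 3 stands lowest of the three, its nearest neighbour being compound 1 at a 19-fold lower number from compound 1 to compound 3 (1.28 log units; beyond the scatter) and compound 2 further off at a 26-fold lower number from compound 2 to compound 3 (1.42 log units; beyond the scatter). Compound 4 `O=C(CC1Oc2cc(O)ccc2C=C1c1ccc(O)cc1)c1cccc2ccccc12` carries naphthalen-1-yl in place of 4-methoxyphenyl on a carbonyl carbon. Among the measured compounds shown here, the steps that bear on this are those leading into compound 3: a 26-fold lower number from compound 2 to compound 3 (1.42 log units; beyond the scatter) and a 19-fold lower number from compound 1 to compound 3 (1.28 log units; beyond the scatter), both large, whereas a 1.4-fold higher number from compound 1 to compound 2 (0.14 log units; within the scatter) was small. Since compound 4 gives up the methoxy that set compound 3 apart, a large step back towards the values of compound 1 and compound 2 is expected, namely an 11-fold higher number from compound 3 to compound 4 (1.02 log units; beyond the scatter). Compound 4 is therefore estimated at 80000 nM, within a range from 15000 nM to 300000 nM.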

Compound 4, half-maximal inhibitory concentration: 106000 nM
Beside the measured number, compound 4's estimate is 1.3-fold (0.12 log units) below it; measured number inside the range.
By their numbers in this assay, from the lowest: compound 3; then compounds 4, 1 and 2 (each within the scatter of the next).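

In this assay, naphthalen-1-yl in place of 4-methoxyphenyl on the carbonyl carbon gives a 14-fold higher number from compound 3 to compound 4 (1.14 log units; beyond the scatter), so a second aromatic ring does not preserve what compound 3 has. The other steps, a 1.9-fold lower number from compound 2 to compound 4 (0.27 log units; within the scatter) and a 1.4-fold lower number from compound 1 to compound 4 (0.14 log units; within the scatter), place naphthalen-1-yl level with 4-ethylphenyl and methyl at this position, leaving compound 3 alone apart from the rest. Nothing available here accounts for this. The compounds shown leave open whether that standing belongs to the methoxy specifically. A hydroxy, an ethoxy or an amine on the same phenyl ring would bear on this.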